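The source may report more compounds than this note shows. Statements on the series, on what has been measured and on what is new or still open speak of the compounds shown alone.

In a functional assay on A549 cells (Homo sapiens) for inhibition, read by MTT assay, with a stated time of 72 h (on this read-out higher numbers stand for weaker inhibition and lower numbers for stronger inhibition), compound 1 (`O=C(CCC(=O)OCCCCCCSc1ccc([N+](=O)[O-])c2nonc12)Nc1ccc(F)cc1`) gives 6300 nM and compound 2 (`O=C(CCC(=O)OCCCCCCSc1ccc([N+](=O)[O-])c2nonc12)Nc1ccc(Br)cc1`) gives 3340 nM while compound 3 (`COc1ccc(NC(=O)CCC(=O)OCCCCCCSc2ccc([N+](=O)[O-])c3nonc23)cc1OC`) gives 3890 nM on the same scale. Compound 3 cannot be separated from the other two, as its steps to both lie within the scatter of repeated measurements.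

Compound 4 (`CN(C)CCCNC(=O)CCC(=O)OCCCCCCSc1ccc([N+](=O)[O-])c2nonc12`) keeps the shared core and changes only the group on the amide-type nitrogen, where the difference from compound 3 is 3-(dimethylamino)propyl in place of 3,4-dimethoxyphenyl on an amide-type nitrogen in full. In words, 3-(dimethylamino)propyl stands in place of 3,4-dimethoxyphenyl.

Two measured steps changed the group at this place, and both are small: a 1.6-fold lower number from compound 1 to compound 3 (0.21 log units; within the scatter) and a 1.2-fold higher number from compound 2 to compound 3 (0.07 log units; within the scatter) stay within the scatter. A third, a 1.9-fold lower number from compound 1 to compound 2 (0.28 log units; within the scatter) on the aromatic ring, also stays within it. However, all three compounds carry an aromatic ring on that nitrogen, so no measurement yet tests an open chain there.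

The small size of these steps gives no reason to predict a shift in either direction, though the untested chain calls for a wide range. The expected result is a 1.0-fold higher number from compound 3 to compound 4 (0.01 log units; within the scatter) in this assay with no change beyond the scatter. Compound 4 is estimated at 4000 nM in this assay with an expected range from 1500 nM to 10000 nM around that figure.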

Compound 4, half-maximal inhibitory concentration: 1580 nM
The estimate for compound 4 lay 2.5-fold (0.40 log units) above the measured number, within the range that was stated.
By their numbers in this assay, from the lowest: compound 4; then compounds 2, 3 and 1 (each within the scatter of the next).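

In this assay, going by these compounds alone, the open chain 3-(dimethylamino)propyl on the amide-type nitrogen gives the first steps at this place that lie beyond the scatter: a 2.5-fold lower number from compound 3 to compound 4 (0.39 log units; beyond the scatter) and a 2.1-fold lower number from compound 2 to compound 4 (0.33 log units; beyond the scatter) and a 4.0-fold lower number from compound 1 to compound 4 (0.60 log units; beyond the scatter) make compound 4 the strongest of the four here, though all three steps are modest. Compounds 1, 2 and 3 all carry an aromatic ring on this nitrogen, whereas compound 4 shows that inhibition in these cells does not depend on such a ring and is somewhat stronger with this chain in its place. The change removes the ring and brings in a nitrogen in a single step, so the result cannot show which of the two matters, and no measurement shown here explains the gain.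

A plain butyl chain with no nitrogen would separate the effect of losing the ring from that of adding the amine. As far as these compounds go, it also remains open how a longer chain carrying the same dimethylamino group, or a propyl chain ending in morpholine or a carboxylic acid, would compare with compound 4.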